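The compounds below may be only part of what the source reports. "The series", "measured", "known", "first", "only" and "open" are said of these compounds alone.

Three compounds have been measured in a functional assay on CHO cells with adenosine receptor A1 (Homo sapiens) as the target, read by cAMP accumulation and immunoassay, with a stated time of 6 min, tested at 10 uM; on this read-out lower numbers stand for a stronger effect and higher numbers for a weaker effect at the one concentration tested:

compound 1 `Nc1scc(CN2CCN(c3ccc([N+](=O)[O-])cc3)CC2)c1C(=O)c1ccc(Cl)cc1`, giving -17%
compound 2 `Nc1scc(CN2CCN(c3ccccc3C(F)(F)F)CC2)c1C(=O)c1ccc(Cl)cc1`, giving -60%
compound 3 `Nc1scc(CN2CCN(c3ccc(F)cc3F)CC2)c1C(=O)c1ccc(Cl)cc1`, giving -82%

Compound 3 stands lowest of the three in this assay. Its nearest neighbour is compound 2, and that gap, a number 22 percentage points lower from compound 2 to compound 3 (beyond the scatter), lies beyond the scatter; the step of a number 65 percentage points lower from compound 1 to compound 3 (beyond the scatter) is larger still. Between compound 1 and compound 2 the step is a number 43 percentage points lower from compound 1 to compound 2 (beyond the scatter).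

Compound 4 `Nc1scc(CN2CCN(c3c(F)cccc3F)CC2)c1C(=O)c1ccc(Cl)cc1` is the unmeasured compound. It differs from compound 3 in one place: 2,6-difluorophenyl in place of 2,4-difluorophenyl on an amine nitrogen in a ring. Within the data shown here, no measured step exchanges one difluorophenyl for another; the steps that bear on it are those that alter the group on the amine nitrogen in the ring, namely the modest step of a number 22 percentage points lower from compound 2 to compound 3 (beyond the scatter) and the two large steps from compound 1. They show that the group on that ring nitrogen can move the number well beyond the scatter, but none of them moves a fluorine within the same ring, so the direction for compound 4 cannot be read from them directly. A modest step upward is expected, because compound 3 sits lowest and compound 2 already gives -60% with a different group at the same place. Compound 4 is therefore expected to give -65%, within -95% to -30%, which means an expected step of a number 17 percentage points higher from compound 3 to compound 4 (beyond the scatter).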

Compound 4, a percentage reported as activity, at one concentration (the size of the read-out at that concentration, not a potency): -80%
Beside the measured number, compound 4's estimate is 15 percentage points above it, and the stated range covers the measured number.
By their numbers in this assay, from the lowest: compounds 3 and 4 (each within the scatter of the next); then compound 2; then compound 1.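

In this assay, among these compounds, the exchange of 2,4-difluorophenyl for 2,6-difluorophenyl on the amine nitrogen in the ring, which no earlier pair contained, gives a number 2 percentage points higher from compound 3 to compound 4 (within the scatter), so the two arrangements of the same atoms cannot be told apart in this read-out. Each difluorophenyl compound stands clear of the other two compounds, as the steps of a number 20 percentage points lower from compound 2 to compound 4 (beyond the scatter) and a number 63 percentage points lower from compound 1 to compound 4 (beyond the scatter) show for the new group, and among these four compounds the two difluorophenyl groups give the lowest numbers, with no compound going against that. No measurement at hand bears on why these two groups read alike.

The compounds shown leave open whether both fluorines are needed at this position, since a plain phenyl, a phenyl with a single fluorine and a phenyl with two chlorine atoms in place of the fluorines do not appear among them. They also leave open whether compound 3 and compound 4 would still read alike in potency, as a single concentration gives only the size of the read-out at that concentration.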